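The compounds below may be only part of what the source reports. "The series", "measured", "known", "first", "only" and "open" are said of these compounds alone.

Measured compounds:
compound 1 `COc1ccc(C(=O)/C=C/c2ccsc2)c2c1C=CC(C)(C)O2`: in a functional assay on HCT-116 cells (Homo sapiens) for antiproliferative activity, read by MTT assay, with a stated time of 24 h (on this read-out lower numbers stand for stronger inhibition and higher numbers for weaker inhibition), compound 1 gives only a limit, > 10000 nM.
compound 2 `COc1ccc(C(=O)/C=C/c2ccc(Cl)c(Cl)c2)c2c1C=CC(C)(C)O2`: in this assay compound 2 gives 9440 nM.

Among the compounds with values here, compound 2 holds the only number among the two values shown; the other value is a limit, (the limit of > 10000 nM in this assay, at which 1 of the 2 values shown sits). Within the data shown here, the one measured step, an at least 1.0-fold lower number from compound 1 to compound 2 (0.02 log units; that floor lies within the scatter), lies within the scatter, so the two aryl groups at that place are not told apart.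

Compound 3 `COc1ccc(C(=O)/C=C/c2cc(Cl)ccc2O)c2c1C=CC(C)(C)O2` is not yet measured. It differs from compound 2 by 5-chloro-2-hydroxyphenyl in place of 3,4-dichlorophenyl on a double-bonded chain carbon bound to a double-bonded chain carbon. Among the measured compounds shown here, the only step that bears on this place is the one from compound 1 to compound 2, and it was within the scatter; no measured step shows a hydroxyl at this place. Accordingly, compound 3 is expected to stay near compound 2, with a step of about a 1.0-fold lower number from compound 2 to compound 3 (0.02 log units; within the scatter), which is none beyond the scatter. Compound 3 is therefore estimated at 9000 nM, between 3000 nM and 30000 nM.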

Compound 3, half-maximal inhibitory concentration: 5240 nM
Compound 3: middle estimate off by 1.7-fold (0.23 log units), on the high side; low and high end bracket the measured number.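

A hydroxyl now stands at this place, in 5-chloro-2-hydroxyphenyl in place of 3,4-dichlorophenyl, and in this assay that change gives a 1.8-fold lower number from compound 2 to compound 3 (0.26 log units; within the scatter) and so leaves the two groups not told apart. The change from thiophen-3-yl to 5-chloro-2-hydroxyphenyl gives an at least 1.9-fold lower number from compound 1 to compound 3 (0.28 log units; that floor lies within the scatter) and so does not tell these two groups apart either. Compound 1 gives a limit and not a number, so that step is only a floor: the limit of > 10000 nM in this assay, at which 1 of the 3 values shown sits.

The compounds shown leave open whether any group on this double-bonded chain carbon moves the number beyond the scatter, as an amine or a carboxylic acid there might. They also leave open what the hydroxyl and the chlorine each contribute, which a plain 2-hydroxyphenyl group at this place would address.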